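This account rests on a few compounds, and the source may have more. Where it says the series, first, only, none or still open, it means among the compounds named here.

Measured compounds:
Compound 1 `COc1cc(C)c(S(=O)(=O)N(C)CCOCC(=O)N2CCN(C3CCN(C4CC4)CC3)CC2)c(C)c1` gives 0.8 nM in an assay on HEK293 cells for displacement of a labelled ligand from B1 bradykinin receptor (Homo sapiens), read by scintillation counting; a higher number here means a weaker inhibitor, a lower number a stronger inhibitor.
Compound 2 `CN(Cc1ccc(C2=NCCN2)cc1)C(=O)COCCN(C)S(=O)(=O)c1c(F)cccc1F` gives 142 nM in this assay.

Among the compounds with values here, compound 1 stands at the lowest of the two numbers in this assay; compound 2 is its only neighbour, and the gap between them is well beyond the scatter. Within the data shown here, the two differ in several places at once, so their values show only that compound 1 is the stronger of the pair and nothing about any single change.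

Compound 3 `COc1cc(C)c(S(=O)(=O)N(C)CCOCC(=O)N2CCN(CC3CCN(C)CC3)CC2)c(C)c1` is derived from compound 1 by one change: (1-methylpiperidin-4-yl)methyl in place of 1-cyclopropylpiperidin-4-yl on an amine nitrogen in a ring. The ring with its nitrogen is kept in the new group, while a three-membered ring leaves and a one-carbon link enters. Among the measured compounds shown here, no measured pair shows this change, so its effect cannot be read from the data. A modest weakening is expected, within or just beyond the scatter, as a 3.1-fold higher number from compound 1 to compound 3 (0.49 log units; beyond the scatter). Compound 3 is therefore estimated at 2.5 nM, within 0.6 nM to 10 nM.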

Compound 3, inhibition constant: 4.5 nM
For compound 3 the middle estimate is 1.8-fold (0.26 log units) below the measured one; the measured number falls inside the stated range.
By their numbers in this assay, from the lowest: compound 1; then compound 3; then compound 2.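

In this assay, within the data shown here, replacing 1-cyclopropylpiperidin-4-yl with (1-methylpiperidin-4-yl)methyl on an amine nitrogen in a ring gives a 5.6-fold higher number from compound 1 to compound 3 (0.75 log units; beyond the scatter), the first comparison in this set that turns on a single place. The group at this position therefore does affect the number, yet the step is modest, and compound 3 still gives 4.5 nM after losing the three-membered ring and gaining a one-carbon link. No measurement offered here explains this step.

The change alters the substituent on the piperidine nitrogen and the link to the core together, so its effect cannot be divided between them. A 1-methylpiperidin-4-yl group without the link, or a (1-cyclopropylpiperidin-4-yl)methyl group with it, would separate the two, and the compounds shown leave that question open.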